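A few compounds are considered here, and "the series" means these few. Any claim that something is new, unique, unknown or untested is made for them only; others in the source may bear on it.

Of the compounds shown here, three sharing one core have been tested in a functional assay on MCF7 cells (Homo sapiens) for antiproliferative activity, read by MTT assay, with a stated time of 72 h; on this read-out higher numbers stand for weaker inhibition and lower numbers for stronger inhibition. Compound 1 `CCc1ccc(C(=O)Nc2ccc3nc(N4CCN(CC)CC4)cc(C)c3c2)cc1` carries a 4-ethylphenyl on the carbonyl carbon and gives 3060 nM. Compound 2 `CCN1CCN(c2cc(C)c3cc(NC(=O)c4cccc(F)c4)ccc3n2)CC1`, with 3-fluorophenyl in that position, gives 8920 nM. Compound 3 `CCN1CCN(c2cc(C)c3cc(NC(=O)c4ccco4)ccc3n2)CC1`, with furan-2-yl there, gives 41200 nM, the highest of the three numbers, so it is the weakest inhibitor of the set.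

Compound 4 `CCN1CCN(c2cc(C)c3cc(NC(=O)c4cccc(C)c4)ccc3n2)CC1` has not yet been measured. It differs from compound 3 in one place: 3-methylphenyl in place of furan-2-yl on a carbonyl carbon. This change runs opposite to the steps already seen: moving from a six-membered ring of carbon only to the five-membered furan-2-yl came with a 13-fold higher number from compound 1 to compound 3 (1.13 log units; beyond the scatter) and with a 4.6-fold higher number from compound 2 to compound 3 (0.66 log units; beyond the scatter), whereas exchanging one substituted phenyl for another gave only a 2.9-fold higher number from compound 1 to compound 2 (0.46 log units; beyond the scatter). Because the return to a six-membered carbon ring mirrors the step of a 4.6-fold higher number from compound 2 to compound 3 (0.66 log units; beyond the scatter) in reverse, a move back toward lower numbers in this assay, clearly beyond the scatter, is expected, roughly a 7.5-fold lower number from compound 3 to compound 4 (0.87 log units; beyond the scatter). Compound 4 is therefore estimated to give about 5500 nM, with a likely range from 1800 nM to 17000 nM.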

Compound 4, half-maximal inhibitory concentration: 7800 nM
Beside the measured number, compound 4's estimate is 1.4-fold (0.15 log units) below it, and the stated range covers the measured number.
By their numbers in this assay, from the lowest: compound 1; then compounds 4 and 2 (each within the scatter of the next); then compound 3.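

In this assay, replacing furan-2-yl with 3-methylphenyl on the carbonyl carbon gives a 5.3-fold lower number from compound 3 to compound 4 (0.72 log units; beyond the scatter) and leaves all three compounds with a six-membered carbon ring lower than the furan-2-yl compound, with none of the four going against this. Methyl and fluoro cannot be told apart on this ring by this read-out, since a 1.1-fold lower number from compound 2 to compound 4 (0.06 log units; within the scatter) stays within the scatter. The 4-ethylphenyl group still holds the lowest number of the set, as a 2.5-fold higher number from compound 1 to compound 4 (0.41 log units; beyond the scatter) shows, so carrying a substituent on a phenyl ring is not enough in itself to match compound 1.

The data shown give no explanation for any of these differences. As far as these compounds go, the 4-ethylphenyl and 3-methylphenyl groups differ in both the chain and its printed ring position, so 4-methylphenyl and 3-ethylphenyl would be the groups to separate those two changes, while an unsubstituted phenyl and a phenyl ring bearing an amine or a carboxylic acid also remain open.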